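Swapping the sulfonyl link for a benzyl link on the cyano series

This account rests on a few compounds, and the source may have more. Where it says the series, first, only, none or still open, it means among the compounds named here.

Of the compounds shown here, three sharing one core have been measured in an ADME assay on L02 cells (Homo sapiens) for cytotoxicity, read by MTT assay, with a stated time of 48 h; a higher number here means a weaker inhibitor, a lower number a stronger inhibitor. Compound 1 `CCN(CC)c1ccc2cc(C(=O)c3ccc(N4CCN(C(=O)CN5CCN(S(=O)(=O)c6ccc(C(F)(F)F)cc6)CC5)CC4)cc3)oc2c1` gives 17000 nM; compound 2 `CCN(CC)c1ccc2cc(C(=O)c3ccc(N4CCN(C(=O)CN5CCN(S(=O)(=O)c6ccc(C#N)cc6)CC5)CC4)cc3)oc2c1` gives 44100 nM; compound 3 `CCN(CC)c1ccc2cc(C(=O)c3ccc(N4CCN(C(=O)CN5CCN(Cc6ccc(C(F)(F)F)cc6)CC5)CC4)cc3)oc2c1` gives 6540 nM. Compound 2 thus shows the highest number of the three, with compound 1 nearest and compound 3 furthest away.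

Compound 4 `CCN(CC)c1ccc2cc(C(=O)c3ccc(N4CCN(C(=O)CN5CCN(Cc6ccc(C#N)cc6)CC5)CC4)cc3)oc2c1` has not yet been measured in this assay. It differs from compound 2 by the change (4-cyanobenzyl in place of (4-cyanophenyl)sulfonyl on an amine nitrogen in a ring). Two of the measured steps bear on this. The step of a 2.6-fold higher number from compound 1 to compound 2 (0.41 log units; beyond the scatter) shows what the cyano does in place of trifluoromethyl on the sulfonyl series. The step of a 6.7-fold lower number from compound 2 to compound 3 (0.83 log units; beyond the scatter) shows the effect of replacing the sulfonyl link by a benzyl link while the aromatic substituent also changes to trifluoromethyl. Compound 4 carries the benzyl link of compound 3 together with the cyano of compound 2, so the large lowering seen in a 6.7-fold lower number from compound 2 to compound 3 (0.83 log units; beyond the scatter) is expected to carry over in part, tempered by the rise seen in a 2.6-fold higher number from compound 1 to compound 2 (0.41 log units; beyond the scatter).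

Compound 4 is therefore expected to give a lower number than compound 2 in this assay, a step of about a 3.2-fold lower number from compound 2 to compound 4 (0.50 log units; beyond the scatter), with an estimated value of 14000 nM and a range from 5000 nM to 40000 nM.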

Compound 4, half-maximal inhibitory concentration: 29600 nM
The estimate for compound 4 lay 2.1-fold (0.33 log units) below the measured number; measured number inside the range.
By their numbers in this assay, from the lowest: compound 3; then compounds 1, 4 and 2 (each within the scatter of the next, the first and the last beyond it).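

With the nitrile held in place, the link on the amine nitrogen can now be read on its own in this assay: 4-cyanobenzyl in place of (4-cyanophenyl)sulfonyl gives a 1.5-fold lower number from compound 2 to compound 4 (0.17 log units; within the scatter), so this pair does not separate the two links. With the benzyl link held in place, cyano in place of trifluoromethyl gives a 4.5-fold higher number from compound 3 to compound 4 (0.66 log units; beyond the scatter), which means the large step earlier seen between compound 2 and compound 3, where both features changed at once, goes with the aromatic substituent rather than with the link in this series. The substituent change now also reads consistently on both links, the sulfonyl and the benzyl: the same change on two cores in this assay, a 2.6-fold higher number (0.41 log units; beyond the scatter) from compound 1 to compound 2 and a 4.5-fold higher number (0.66 log units; beyond the scatter) from compound 3 to compound 4, 1.7-fold (0.24 log units) apart, within the scatter of two such steps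

From the compounds shown here alone, the four compounds carry only trifluoromethyl and nitrile on that aromatic ring, so how an amine or a carboxylic acid in the same place would read in this assay remains open. Also open, going by these compounds, is whether a longer chain between the ring nitrogen and the aromatic ring would leave the number as little changed as the switch from sulfonyl to benzyl did with the nitrile present.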